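Hydroxy Substitution Repeated on a Second Urea Core

A few compounds are considered here, and "the series" means these few. Any claim that something is new, unique, unknown or untested is made for them only; others in the source may bear on it.

Measured so far:
compound 1, `CC(C)n1cnnc1-c1cccc(NC(=O)Nc2nccc3ccccc23)n1`: 201 nM
compound 2, `CC(C)n1cnnc1-c1cccc(NC(=O)Nc2ncc3ccccc3n2)n1`: 2910 nM
compound 3, `C[C@H](CO)n1cnnc1-c1cccc(NC(=O)Nc2nccc3ccccc23)n1`: 264 nM

In an assay on isolated protein for inhibition of mitogen-activated protein kinase kinase kinase 6 (Homo sapiens) (on this read-out higher numbers stand for weaker inhibition and lower numbers for stronger inhibition), compound 1 gives 201 nM and compound 3 gives 264 nM. The change between them is hydroxy in place of hydrogen on a saturated chain carbon, two bonds along the chain from an aromatic nitrogen and it made a 1.3-fold higher number from compound 1 to compound 3 (0.12 log units; within the scatter). Compound 2 carries a different core; how that core differs from the core of compound 1 is not broken down here. In this assay compound 2 gives 2910 nM, the highest number of the three. Compound 4, `C[C@H](CO)n1cnnc1-c1cccc(NC(=O)Nc2ncc3ccccc3n2)n1`, arises from compound 2 by the same change, (hydroxy in place of hydrogen on a saturated chain carbon, two bonds along the chain from an aromatic nitrogen). Because the same change made a 1.3-fold higher number from compound 1 to compound 3 (0.12 log units; within the scatter), the step to compound 4 is expected to be a 1.2-fold higher number from compound 2 to compound 4 (0.09 log units; within the scatter). Compound 4 is therefore estimated to give about 3600 nM, between 1800 nM and 7500 nM.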

Compound 4, half-maximal inhibitory concentration: 7170 nM
Compound 4: middle estimate off by 2.0-fold (0.30 log units), on the low side, within the range that was stated.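

On the second core, putting hydroxy in place of hydrogen gives a 2.5-fold higher number from compound 2 to compound 4 (0.39 log units; beyond the scatter) in this assay. Set beside the step on the first core, this step cannot be told apart from it: the same change on two cores in this assay, a 1.3-fold higher number (0.12 log units; within the scatter) from compound 1 to compound 3 and a 2.5-fold higher number (0.39 log units; beyond the scatter) from compound 2 to compound 4, 1.9-fold (0.27 log units) apart, within the scatter of two such steps. The change therefore carried over between these two cores within the precision of the measurements, but two pairs do not show that it would behave the same way on any further core, and they do not explain why the second step alone lies beyond the scatter.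

The compounds shown leave open how other groups would compare in the same place. An amine or a methoxy in place of the hydroxy, or a longer chain carrying the hydroxy, could be compared on both cores.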